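A few compounds are considered here, and "the series" means these few. Any claim that something is new, unique, unknown or untested is made for them only; others in the source may bear on it.

Measured so far in a functional assay on CHO-K1 cells for antagonist activity at C-X-C chemokine receptor type 3 (Homo sapiens), read by FLIPR, with a stated time of 10 min, in the presence of a further agent that is not named here; on this read-out lower numbers stand for stronger inhibition and higher numbers for weaker inhibition:
compound 1 `C[C@@H]1CN(c2sc(C(F)(F)F)nc2-c2nc3ccccc3[nH]2)CCN1C(=O)Cn1ccc(C(=O)O)n1` gives 2100 nM;
compound 2 `Cc1nc(C)n(CC(=O)N2CCN(c3sc(C(F)(F)F)nc3-c3nc4ccc(OC5COC5)cc4[nH]3)C[C@H]2C)n1` gives 68 nM;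
compound 3 `C[C@@H]1CN(c2sc(C(F)(F)F)nc2-c2nc3ccc(CO)cc3[nH]2)CCN1C(=O)Cn1cnc2cccnc21` gives 4.6 nM.

Compound 1 stands highest of the three numbers; compound 2 lies well below it and compound 3 further still, both gaps beyond the scatter. Compound 4 `C[C@@H]1CN(c2sc(C(F)(F)F)nc2-c2nc3ccccc3[nH]2)CCN1C(=O)Cn1cc(C2CCN(C)CC2)cn1` has not yet been measured. It differs from compound 1 in one place: 4-(1-methylpiperidin-4-yl)-1H-pyrazol-1-yl in place of 3-carboxy-1H-pyrazol-1-yl on a saturated chain carbon bound to a carbonyl carbon. Among the measured compounds shown here, no measured pair isolates this change. Compounds 2 and 3 carry other groups on the saturated chain carbon bound to a carbonyl carbon and give far lower numbers, though they also differ from compound 1 elsewhere on the shared core. Compound 4 is therefore expected to give a lower number than compound 1, a step of a 14-fold lower number from compound 1 to compound 4 (1.15 log units; beyond the scatter), beyond the scatter. For compound 4 the estimate in this assay is 150 nM, with a range from 30 nM to 800 nM.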

Compound 4, half-maximal inhibitory concentration: 15 nM
Compound 4: middle estimate off by 10-fold (1.00 log units), on the high side, and the stated range ends above it.
By their numbers in this assay, from the lowest: compound 3; then compound 4; then compound 2; then compound 1.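

In this assay, among the compounds shown here, 4-(1-methylpiperidin-4-yl)-1H-pyrazol-1-yl in place of 3-carboxy-1H-pyrazol-1-yl on a saturated chain carbon bound to a carbonyl carbon gives a 140-fold lower number from compound 1 to compound 4 (2.15 log units; beyond the scatter), the first step that isolates this place with the shared core unchanged. The change at this place alone is therefore enough to move the number by a large step. Nothing measured here explains the step.

From the compounds shown here alone, whether it belongs to losing the carboxylic acid or to gaining the 1-methylpiperidin-4-yl group stays open. An unsubstituted pyrazol-1-yl or a methyl ester in the same place would separate the two.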